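The source may hold more compounds than are shown below. What is called first, only, known or untested is meant among the compounds shown, and "the series" means these compounds.

Compound 1 `COc1cc(/C=C\Cc2cc(O)c3ccoc3c2)cc(OC)c1OC`: 38 nM
Compound 2 `COc1cc(/C=C\Cc2cc(OP(=O)(O)O)c3ccsc3c2)cc(OC)c1OC`: 639 nM

In a functional assay on MCF7 cells (Homo sapiens) for antiproliferative activity (a higher number here means a weaker inhibitor, a lower number a stronger inhibitor), compound 1 has the lower of the two numbers, which makes it the stronger inhibitor of this pair by a margin beyond the scatter. Compound 3 `COc1cc(/C=C\Cc2cc(OP(=O)(O)O)c3ccoc3c2)cc(OC)c1OC` keeps the core of compound 1 and changes one place: a group of 4 heavy atoms (3 oxygen, 1 phosphorus; no ring) in place of a hydrogen atom, on an oxygen on an aromatic ring. Within the data shown here, no measured pair shows this change alone. Compound 2 also carries this group and gives 639 nM, so a weaker result, beyond the scatter, is expected in this assay. The estimated step is a 5.3-fold higher number from compound 1 to compound 3 (0.72 log units; beyond the scatter). Compound 3 is expected at 200 nM, within a range of 60 nM to 640 nM.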

Compound 3, half-maximal inhibitory concentration: 646 nM
Compound 3: the middle estimate sits 3.2-fold (0.51 log units) below what was measured; the whole stated range lies below it.
By their numbers in this assay, from the lowest: compound 1; then compounds 2 and 3 (each within the scatter of the next).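

In this assay, putting the group of 4 heavy atoms (3 oxygen, 1 phosphorus) in place of the hydrogen atom on this oxygen on an aromatic ring gives a 17-fold higher number from compound 1 to compound 3 (1.23 log units; beyond the scatter) as a direct reading of this change alone. This single change therefore makes a large difference, with compound 1 the stronger inhibitor of the pair. Nothing measured here explains the loss. On these data alone, what remains open is whether a methyl group or an acetyl group on the same oxygen would give a number closer to compound 1 or to compound 3.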